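The source may hold more compounds than are shown below. What is called first, only, known or untested is meant among the compounds shown, and "the series" means these compounds.

Measured in a functional assay (aorta) with Rattus norvegicus as the target; on this read-out higher numbers stand for an effect only at larger amounts of compound and lower numbers for an effect already at smaller amounts:
- compound 1 `C/N=C(/S)C1=CC(C)(C(F)(F)F)Oc2ccc([N+](=O)[O-])cc21`: 0.302 nM
- compound 2 `CNC(=O)C1=CC(C)(C)Oc2ccc([N+](=O)[O-])cc21`: 10.7 nM
- compound 3 `CNC(=O)C1=CC(C)(CF)Oc2ccc([N+](=O)[O-])cc21`: 8.91 nM

Compound 3 stands level with compound 2 within the scatter, while compound 1 lies well below both. Compound 4 `CNC(=O)C1=CC(C)(C(F)(F)F)Oc2ccc([N+](=O)[O-])cc21` carries trifluoromethyl in place of fluoromethyl on a saturated ring carbon. Going by the values given here, the one measured step of this kind is a 1.2-fold lower number from compound 2 to compound 3 (0.08 log units; within the scatter), and it stays within the scatter. Among the compounds with values here, compound 1, the only measured compound bearing trifluoromethyl, shows 0.302 nM, yet it differs from compound 3 in more than this group, so it offers only a weak hint. A moderate fall in this assay is therefore expected, estimated as a 3.0-fold lower number from compound 3 to compound 4 (0.47 log units; beyond the scatter). Compound 4 is expected at 3 nM, with an estimated range of 0.7 nM to 10 nM.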

Compound 4, half-maximal effective concentration: 2.69 nM
Estimate against measurement, compound 4: 1.1-fold (0.05 log units) above; the measured number falls inside the stated range.
By their numbers in this assay, from the lowest: compound 1; then compound 4; then compounds 3 and 2 (each within the scatter of the next).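

In this assay the position now responds to fluorine: a 3.3-fold lower number from compound 3 to compound 4 (0.52 log units; beyond the scatter) and a 4.0-fold lower number from compound 2 to compound 4 (0.60 log units; beyond the scatter) both lie beyond the scatter, whereas a 1.2-fold lower number from compound 2 to compound 3 (0.08 log units; within the scatter) stayed within it. With trifluoromethyl held constant, placing the oxygen-bearing group for the sulfur-bearing group on the double-bonded ring carbon gives an 8.9-fold higher number from compound 1 to compound 4 (0.95 log units; beyond the scatter), so trifluoromethyl alone does not set the value. The compounds shown offer no measurement that explains these steps. From the compounds shown here alone, whether an ethyl group or a longer chain on this saturated ring carbon would give a similar step remains open.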